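This account rests on a few compounds, and the source may have more. Where it says the series, first, only, none or still open, it means among the compounds named here.

Working notes on the series. Compound 1 `Brc1ccc2[nH]cc(C(c3ccccc3)c3c[nH]c4ccc(Br)cc34)c2c1` is the reference; in a functional assay on A549 cells (Homo sapiens) for inhibition, read by MTT assay, with a stated time of 48 h (on this read-out lower numbers stand for stronger inhibition and higher numbers for weaker inhibition), compound 1 gives 7500 nM, the lowest of the three numbers in hand. Compound 2 `Oc1ccc(C(c2c[nH]c3ccc(Br)cc23)c2c[nH]c3ccc(Br)cc23)cc1` gives 9000 nM in this assay, and the step of a 1.2-fold higher number from compound 1 to compound 2 (0.08 log units; within the scatter). Compound 3 `COc1ccc(C(c2c[nH]c3ccc(Br)cc23)c2c[nH]c3ccc(Br)cc23)c(OC)c1` gives 100000 nM in this assay; the step of a 13-fold higher number from compound 1 to compound 3 (1.12 log units; beyond the scatter), and the step of an 11-fold higher number from compound 2 to compound 3 (1.05 log units; beyond the scatter).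

Compound 4 `Brc1ccc2[nH]cc(C(c3c[nH]c4ccc(Br)cc34)C3CCCCC3)c2c1` is not yet measured. Relative to compound 1, the change is that (cyclohexyl in place of phenyl on a saturated chain carbon bound to two aromatic carbons). Among the compounds with values here, no measured step exchanges phenyl for a non-aromatic ring at this carbon, so the bearing of the earlier steps is indirect: the ring on the saturated chain carbon has been varied only once, and that variation weakened inhibition. A modest weakening in this assay is therefore expected for compound 4, because a 13-fold higher number from compound 1 to compound 3 (1.12 log units; beyond the scatter) shows this carbon to be sensitive to the ring it carries, though the exchange there was not the one at hand; the expected step is a 2.0-fold higher number from compound 1 to compound 4 (0.30 log units; within the scatter). Compound 4 is estimated at 15000 nM, with a range from 5000 nM to 50000 nM.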

Compound 4, half-maximal inhibitory concentration: 5500 nM
For compound 4 the middle estimate is 2.7-fold (0.44 log units) above the measured one; measured number inside the range.
By their numbers in this assay, from the lowest: compounds 4, 1 and 2 (each within the scatter of the next); then compound 3.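

The step of a 1.4-fold lower number from compound 1 to compound 4 (0.13 log units; within the scatter) and the step of a 1.6-fold lower number from compound 2 to compound 4 (0.21 log units; within the scatter) show that in this assay the ring on the saturated chain carbon bound to two aromatic carbons need not be aromatic for the number to stay within the scatter. The step of an 18-fold lower number from compound 3 to compound 4 (1.26 log units; beyond the scatter) sets the 2,4-dimethoxyphenyl group of compound 3 apart from all three other rings shown at this carbon, so the sensitivity seen earlier does not extend to the exchange of phenyl for cyclohexyl. No measurement in hand bears on the reason for these numbers.

Still open, as far as these compounds go, is how this carbon responds to a ring carrying an amine, such as piperidinyl, to a carboxylic acid on the cyclohexyl ring, or to an open chain such as n-butyl in place of a ring. Also open, from the compounds shown here alone, is whether one methoxy group on the phenyl ring would be enough to raise the number as in compound 3.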